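Swapping an Oxadiazole for a Thiophene on a Sulfoxide

This account rests on a few compounds, and the source may have more. Where it says the series, first, only, none or still open, it means among the compounds named here.

Two sulfoxides have been measured in an assay on HEK293 cells for inhibition of sodium-dependent dopamine transporter (Homo sapiens), read by scintillation counting, with stated times of 5 min and 1 min; on this read-out higher numbers stand for weaker inhibition and lower numbers for stronger inhibition. Compound 1 `[O-][S+](Cc1cccs1)C(c1ccc(Cl)cc1)c1ccc(Cl)cc1` gives 7200 nM in this assay. Compound 2 `Cc1noc(C[S+]([O-])C(c2ccccc2)c2ccccc2)n1` gives 56700 nM in this assay, the higher of the two numbers and so the weaker inhibitor, with compound 1 standing well below it. Compound 3 `[O-][S+](Cc1ccsc1)C(c1ccccc1)c1ccccc1` shares its core with compound 2 and differs from it in one place: thiophen-3-yl in place of 3-methyl-1,2,4-oxadiazol-5-yl on a saturated chain carbon bound to a sulfur. Through this change compound 3 comes to resemble compound 1 in the group on the sulfur, although the two differ elsewhere in the core. Given that compound 1 reaches 7200 nM with a related group, compound 3 is expected to show a lower number than compound 2. The expected step of a 3.8-fold lower number from compound 2 to compound 3 (0.58 log units; beyond the scatter) is beyond the scatter yet falls short of the level of compound 1. Compound 3 is therefore estimated at 15000 nM, with a likely range from 5000 nM to 45000 nM.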

Compound 3, half-maximal inhibitory concentration: 3000 nM
For compound 3 the middle estimate is 5.0-fold (0.70 log units) above the measured one, outside the stated range (below it).
By their numbers in this assay, from the lowest: compound 3; then compound 1; then compound 2.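

In this assay, the group on the saturated chain carbon bound to a sulfur proves to matter a great deal: with the rest of the molecule unchanged, thiophen-3-yl in place of 3-methyl-1,2,4-oxadiazol-5-yl gives a 19-fold lower number from compound 2 to compound 3 (1.28 log units; beyond the scatter), a large step. Within the data shown here, this is the first pair that differs in one place only, so it is the first time a single change can be read on its own. That one change still swaps several features together, including the hetero atoms of the ring and the count of hydrogen-bond acceptors, and the pair cannot separate them.

Going by these compounds, compound 1 differs from compound 3 in more than one place, so that pair cannot be read as one change, and whether an amine or a longer chain at this position would keep the lower number remains open. Nothing measured here explains the size of the step.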